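Benzofuran for furan on two related nucleoside cores

The compounds below may be only part of what the source reports. "The series", "measured", "known", "first", "only" and "open" are said of these compounds alone.

Compound 1, `O=c1[nH]cnc2c1c(-c1ccoc1)cn2[C@@H]1O[C@H](CO)[C@@H](O)[C@H]1O`: in a functional assay on CEM-DNR-bulk cells (Homo sapiens), read by MTT assay, with a stated time of 72 h (on this read-out lower numbers stand for stronger inhibition and higher numbers for weaker inhibition), compound 1 gives > 20000 nM, which is a limit of the assay and not a number.
Compound 2, `O=c1[nH]cnc2c1c(-c1cc3ccccc3o1)cn2[C@@H]1O[C@H](CO)[C@@H](O)[C@H]1O`: compound 2 gives > 20000 nM, again a limit of the assay.
Compound 3, `Nc1nc(N)c2c(-c3ccoc3)cn([C@@H]3O[C@H](CO)[C@@H](O)[C@H]3O)c2n1`: compound 3 gives > 20000 nM, again a limit of the assay.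

Compound 4, `Nc1nc(N)c2c(-c3cc4ccccc4o3)cn([C@@H]3O[C@H](CO)[C@@H](O)[C@H]3O)c2n1`, has not yet been measured. From compound 1 to compound 2 the change is 1-benzofuran-2-yl in place of furan-3-yl on an aromatic carbon. The step that the two limits leave unreadable from compound 1 to compound 2 cannot be read, since the limit of > 20000 nM in this assay, at which 3 of the 3 values shown sit, places both ends at the same limit. The cores of compound 1 and compound 3 differ, but that difference is not broken down here. From compound 3 to compound 4 the change is 1-benzofuran-2-yl in place of furan-3-yl on an aromatic carbon, the same change at the same kind of place as before.

Compound 4 is expected to stay at the limit too, so the expected step that the limit leaves unreadable from compound 3 to compound 4 is essentially flat. This rests on the unreadable step that the two limits leave unreadable from compound 1 to compound 2 and on (the limit of > 20000 nM in this assay, at which 3 of the 3 values shown sit), where every measured value sits. The estimate for compound 4 is therefore 25000 nM, most likely reported again only as a limit.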

Compound 4, half-maximal inhibitory concentration: > 20000 nM
Compound 4 was reported as a limit; the forecaster's own chance of this, stated with the estimate: 85%; the middle value does not contradict the limit.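

Compound 3 and compound 4 sit at the same limit, which is not a number, so the change from furan-3-yl to 1-benzofuran-2-yl gives no readable step between them: the limit of > 20000 nM in this assay, at which 4 of the 4 values shown sit.

The compounds shown leave open whether this change alters inhibition on either core, and how strongly any of the four compounds acts on these cells.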